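A few compounds are considered here, and "the series" means these few. Any claim that something is new, unique, unknown or untested is made for them only; others in the source may bear on it.

Measured compounds:
- compound 1 `S=c1oc(-c2ccc3c(c2)OCCO3)nn1CN1CCN(c2ccc(Cl)cc2)CC1`; in a functional assay on HepG2 cells (Homo sapiens) for antiproliferative activity, read by MTT assay, with a stated time of 48 h (on this read-out higher numbers stand for weaker inhibition and lower numbers for stronger inhibition), compound 1 gives only a limit, > 50000 nM
- compound 2 `COc1ccc(N2CCN(Cn3nc(-c4ccc5c(c4)OCCO5)oc3=S)CC2)cc1`; in this assay compound 2 gives only a limit, > 50000 nM

Compound 2 stands at the limit of this assay, as does every value shown so far, which is the position described by the limit of > 50000 nM in this assay, at which 2 of the 2 values shown sit. Among the measured compounds shown here, the one measured step, a step that the two limits leave unreadable from compound 1 to compound 2, runs between two limits and its size cannot be read.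

Compound 3 `S=c1oc(-c2ccc3c(c2)OCCO3)nn1CN1CCN(c2ccccc2Cl)CC1` is not yet measured. It differs from compound 2 by 2-chlorophenyl in place of 4-methoxyphenyl on an amine nitrogen in a ring. For the measured compounds named here, no measured step bears on this change in a readable way: the step from compound 1 to compound 2 already concerns a chloro against a methoxy group and left no number. Both measured compounds sit at the limit, so no direction can be taken from them. Compound 3 is therefore expected to remain at or near the limit, an estimate of 50000 nM with a range from 20000 nM to 120000 nM; the step this estimate implies, a number no higher from compound 2 to compound 3 (the limit leaves the size open), is expected to stay within the scatter.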

Compound 3, half-maximal inhibitory concentration: 11400 nM
Compound 3: middle estimate off by 4.4-fold (0.64 log units), on the high side; measured number outside the range, below it.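

On the aryl group at the amine nitrogen of the piperazine-type ring, this assay now gives a first readable response: 2-chlorophenyl in place of 4-methoxyphenyl gives an at least 4.3-fold lower number from compound 2 to compound 3 (0.64 log units; beyond the scatter). Moving to 2-chlorophenyl from 4-chlorophenyl gives an at least 4.3-fold lower number from compound 1 to compound 3 (0.64 log units; beyond the scatter), so within this pair a chloro group on the phenyl is not enough by itself, and the result depends on which of the two chlorophenyl groups is present. Only compound 3 has a number rather than a limit: the limit of > 50000 nM in this assay, at which 2 of the 3 values shown sit.

On these data alone, the step between the two compounds at the limit still cannot be read, and both readable steps start from a limit, so their true sizes remain open. Also open, as far as these compounds go, is whether the chloro of the 2-chlorophenyl group is needed at all, which a plain phenyl, or a fluoro or methyl group in its place, would address.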